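The source may hold more compounds than are shown below. What is called first, only, known or untested is meant among the compounds shown, and "the series" means these compounds.

Compound 1, with structure `O=C(c1ccc2cccc(OCc3ccc(B(O)O)cc3)c2n1)N1CCC(Oc2no[n+]([O-])c2S(=O)(=O)c2ccccc2)CC1`, and compound 2, with structure `CC1(C)OB(c2ccc(COc3cccc4ccc(C(=O)N5CCC(Oc6no[n+]([O-])c6S(=O)(=O)c6ccccc6)CC5)nc34)cc2)OC1(C)C`, share one core and differ in a single place: a group of 9 heavy atoms (6 carbon, 1 boron, 2 oxygen; one five-membered non-aromatic ring with 3 hetero atoms) in place of a group of 3 heavy atoms (1 boron, 2 oxygen; no ring), on an aromatic carbon. In a functional assay on PANC-1 cells (Homo sapiens) for cytotoxicity, read by MTT assay, with a stated time of 48 h (a higher number here means a weaker inhibitor, a lower number a stronger inhibitor), compound 1 gives 16600 nM, and compound 2 gives 13200 nM, so the change made a 1.3-fold lower number from compound 1 to compound 2 (0.10 log units; within the scatter). Compound 3, with structure `O=C(NCCCOc1no[n+]([O-])c1S(=O)(=O)c1ccccc1)c1ccc2cccc(OCc3ccc(B(O)O)cc3)c2n1`, is built on a different core; the difference between the two cores is not broken down here. In this assay compound 3 gives 10500 nM. Compound 4, with structure `CC1(C)OB(c2ccc(COc3cccc4ccc(C(=O)NCCCOc5no[n+]([O-])c5S(=O)(=O)c5ccccc5)nc34)cc2)OC1(C)C`, carries the same change relative to compound 3: a group of 9 heavy atoms (6 carbon, 1 boron, 2 oxygen; one five-membered non-aromatic ring with 3 hetero atoms) in place of a group of 3 heavy atoms (1 boron, 2 oxygen; no ring), on an aromatic carbon. Because the earlier step was a 1.3-fold lower number from compound 1 to compound 2 (0.10 log units; within the scatter), a step of about the same size is expected from compound 3 to compound 4, a 1.2-fold lower number from compound 3 to compound 4 (0.09 log units; within the scatter), which rests on one example only. Compound 4 is therefore estimated at 8500 nM in this assay, within the range 4500 nM to 16000 nM.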

Compound 4, half-maximal inhibitory concentration: 17100 nM
Compound 4: the middle estimate sits 2.0-fold (0.30 log units) below what was measured, outside the stated range (above it).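

Putting the group with the five-membered non-aromatic ring in place of the ring-free boron group gives a 1.6-fold higher number from compound 3 to compound 4 (0.21 log units; within the scatter). Set beside the earlier step, this gives no sign that the change acts differently on the two cores: the same change on two cores in this assay, a 1.3-fold lower number (0.10 log units; within the scatter) from compound 1 to compound 2 and a 1.6-fold higher number (0.21 log units; within the scatter) from compound 3 to compound 4, 2.0-fold (0.31 log units) apart, within the scatter of two such steps. In this assay, neither step stands clear of the scatter, so no effect of the change is shown on either core, and two pairs of compounds cannot show that it would be equally without effect on other cores.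

The compounds shown leave open whether an amine or a carboxylic acid at this place on the aromatic ring would give a step beyond the scatter. They also leave open what a longer chain on the core of compound 3 would do.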